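This account rests on a few compounds, and the source may have more. Where it says the series, first, only, none or still open, it means among the compounds named here.

Compound 1 `COc1cncc(C2=CC3CC(C2)CN(C)C3)c1` gives 0.6 nM in an in vitro assay on SH-EP1 cells for displacement of a labelled ligand from Neuronal acetylcholine receptor; alpha4/beta2 (Homo sapiens); on this read-out higher numbers stand for weaker inhibition and lower numbers for stronger inhibition.
Compound 2 `CN1C[C@H]2C=C(c3cccnc3)C[C@H](C2)C1` gives 2.1 nM.
Compound 3 `C1=C(c2cnccn2)CC2CNCC1C2` gives 1.1 nM.

Among these three measured compounds, compound 1 has the lowest number in this assay. Its nearest neighbour is compound 3, whose value is higher by an amount that stays within the usual scatter of such measurements, so the two cannot be ordered on this basis. Compound 2 lies furthest away, with a number higher than that of compound 1 by a margin beyond the scatter.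

Compound 4 `COc1cncc(C2=CC3CNCC(C2)C3)c1` is not yet measured. It differs from compound 1 in one place: hydrogen in place of methyl on an amine nitrogen in a ring. For the measured compounds named here, no pair of measured compounds shows this exact change on its own, so the size of the step cannot be read off directly; compound 2 carries the methyl and compound 3 carries the hydrogen, but they also differ from each other in the aromatic ring. From compound 1 to compound 4 a small step is expected, most likely none beyond the scatter, and if anything toward a slightly lower number: a 1.2-fold lower number from compound 1 to compound 4 (0.08 log units; within the scatter). For compound 4 the expected value in this assay is 0.5 nM, with a range from 0.15 nM to 1.8 nM.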

Compound 4, inhibition constant: 0.3 nM
Estimate against measurement, compound 4: 1.7-fold (0.22 log units) above; low and high end bracket the measured number.
By their numbers in this assay, from the lowest: compounds 4, 1, 3 and 2 (each within the scatter of the next, the first and the last beyond it).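

For the compounds shown here, removing the methyl from the amine nitrogen of the ring gives the first direct reading of this change: in this assay, the step is a 2.0-fold lower number from compound 1 to compound 4 (0.30 log units; within the scatter). On the core of compound 1, this nitrogen can therefore carry either methyl or hydrogen without the two numbers separating beyond the usual scatter of repeated measurements, so compound 1 and compound 4 cannot be ordered on this basis. No measured evidence bears on this result, so the data offer no explanation for it.

The compounds shown leave open what happens when a larger group, such as an ethyl, a benzyl or a longer chain, stands on this nitrogen, since only methyl and hydrogen appear there. They also leave open whether the exchange of methyl for hydrogen gives a similar step when the aromatic ring carries no methoxy group or is replaced, because compound 2 and compound 3 differ from each other in that ring as well as on the nitrogen.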